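From Cyclohexyl to 2-Bromophenyl on a Sulfur Side Chain

This account rests on a few compounds, and the source may have more. Where it says the series, first, only, none or still open, it means among the compounds named here.

Three related compounds share one core and have been tested in a functional assay on MCF7 cells (Homo sapiens) for inhibition, read by MTT assay, with a stated time of 72 h; a higher number here means a weaker inhibitor, a lower number a stronger inhibitor. Compound 1 (`Cc1cc(Nc2cc(-c3cccs3)[nH]n2)n2nc(SCc3ccc(Br)cc3)nc2n1`) gives 5370 nM, and compound 2 (`Cc1cc(Nc2ccn(Cc3ccccc3)n2)n2nc(SCc3ccc(Br)cc3)nc2n1`) gives 15800 nM. Compound 3 (`Cc1cc(Nc2cc(-c3ccccc3)[nH]n2)n2nc(SCC3CCCCC3)nc2n1`) reads > 50000 nM, which is a limit of the test and not a number. Its true position is therefore unknown.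

Compound 4 (`Cc1cc(Nc2cc(-c3ccccc3)[nH]n2)n2nc(SCc3ccccc3Br)nc2n1`) has not yet been measured. It keeps the structure of compound 3 except for one change, with 2-bromophenyl in place of cyclohexyl on a saturated chain carbon bound to a sulfur. For the measured compounds named here, no pair of measured compounds differs in just one place, so there is no direct measure of what such a change does.

The best available guide is that two compounds with a bromine-bearing benzyl group on the sulfur gave real numbers, compound 1 at 5370 nM and compound 2 at 15800 nM. A move towards a stronger inhibitor, meaning a lower number, is therefore expected, and the estimated step is an at least 4.1-fold lower number from compound 3 to compound 4 (0.61 log units; beyond the scatter). For compound 4, the estimated value is 12000 nM, with an expected range from 3500 nM to 40000 nM.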

Compound 4, half-maximal inhibitory concentration: 3020 nM
Compound 4: middle estimate off by 4.0-fold (0.60 log units), on the high side, and the stated range ends above it.
By their numbers in this assay, from the lowest: compounds 4 and 1 (each within the scatter of the next); then compound 2. At a limit, above all of these: compound 3.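

In this assay, for the compounds shown here, putting 2-bromophenyl in place of cyclohexyl on a saturated chain carbon bound to a sulfur gives an at least 16-fold lower number from compound 3 to compound 4 (1.21 log units; beyond the scatter), and this is the first direct reading of a change at this place. It shows that this place on the side chain is not indifferent to the group it carries: exchanging one six-membered ring of carbon for another, now aromatic and bearing a bromine, takes the series from a limit to a real number. The true size of the step stays open-ended because compound 3 gives a limit and not a number: the limit of > 50000 nM in this assay, at which 1 of the 4 values shown sits.

The change alters two things at once, the ring type and the bromine, so the compounds shown cannot say which of them matters, or whether both do; a plain phenyl or a 2-chlorophenyl group at the same place would help to separate the two. Going by these compounds, compound 1 and compound 2 differ from compound 4 in more than one place, so they cannot settle this, and how an amine or a carboxylic acid on that ring would read also remains unknown.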